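Notes on compound 4: benzyl for phenyl on sulfonamide nitrogen

The compounds below may be only part of what the source reports. "The series", "measured", "known", "first", "only" and "open" are said of these compounds alone.

Compound 1 `NS(=O)(=O)N1CCC(C(=O)/C(=N/O)Nc2ccc(F)c(Br)c2)CC1` gives 63 nM in an assay for inhibition of Indoleamine 2,3-dioxygenase 1 (Homo sapiens), with a stated time of 1 h; on this read-out higher numbers stand for weaker inhibition and lower numbers for stronger inhibition.
Compound 2 `O=C(/C(=N/O)Nc1ccc(F)c(Br)c1)C1CCN(C(=O)NCc2ccccc2)CC1` gives 43 nM in this assay.
Compound 3 `O=C(/C(=N/O)Nc1ccc(F)c(Br)c1)C1CCN(S(=O)(=O)Nc2ccccc2)CC1` gives 98 nM in this assay.

Compound 3 stands highest of the three numbers, with a 1.6-fold higher number from compound 1 to compound 3 (0.19 log units; within the scatter) and a 2.3-fold higher number from compound 2 to compound 3 (0.36 log units; beyond the scatter). Compound 4 `O=C(/C(=N/O)Nc1ccc(F)c(Br)c1)C1CCN(S(=O)(=O)NCc2ccccc2)CC1` differs from compound 3 by benzyl in place of phenyl on a sulfonamide nitrogen. Among the compounds with values here, no measured step matches this change directly. The nearest is a 1.6-fold higher number from compound 1 to compound 3 (0.19 log units; within the scatter), where placing phenyl on the same sulfonamide nitrogen gave a step within the scatter; the other known change, at the ring amine nitrogen, a 2.3-fold higher number from compound 2 to compound 3 (0.36 log units; beyond the scatter), was modest. Lengthening phenyl to benzyl on the sulfonamide nitrogen is therefore expected to give no step beyond the scatter in this assay, that is a 1.3-fold lower number from compound 3 to compound 4 (0.12 log units; within the scatter). Compound 4 is expected at 75 nM, in the range 30 nM to 190 nM.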

Compound 4, half-maximal inhibitory concentration: 24 nM
Compound 4: the middle estimate sits 3.1-fold (0.49 log units) above what was measured; the measured number lies below the stated range.
By their numbers in this assay, from the lowest: compounds 4, 2, 1 and 3 (each within the scatter of the next, the first and the last beyond it).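

The step of a 4.1-fold lower number from compound 3 to compound 4 (0.61 log units; beyond the scatter) on moving from phenyl to benzyl shows that this sulfonamide nitrogen distinguishes between two aromatic groups, which the within-scatter step from hydrogen to phenyl did not reveal. The step of a 2.6-fold lower number from compound 1 to compound 4 (0.42 log units; beyond the scatter) with benzyl in place of hydrogen shows that substitution here can also lower the number beyond the scatter. No measured evidence bears on the reason for either step.

Still open, on these data alone, is how a phenethyl chain on this nitrogen would read, or a benzyl group carrying a carboxylic acid or an amine.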